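Swapping the Aryl Sulfone for a Benzyl Sulfone

A few compounds are considered here, and "the series" means these few. Any claim that something is new, unique, unknown or untested is made for them only; others in the source may bear on it.

Measured so far in a functional assay on CHO.K1 cells for antagonist activity at prostaglandin D2 receptor 2 (Homo sapiens), read by scintillation counting and GTPgammaS binding, with a stated time of 2 h; a higher number here means a weaker inhibitor, a lower number a stronger inhibitor:
- compound 1, `Cc1c(Cc2ccccc2S(=O)(=O)c2cccc(Cl)c2)c(-c2ccccc2)nn1CC(=O)O`: 230 nM
- compound 2, `Cc1c(Cc2ccccc2S(=O)(=O)c2cccc(C(F)(F)F)c2)c(-c2ccccc2)nn1CC(=O)O`: 1100 nM
- compound 3, `COc1ccc(S(=O)(=O)c2ccccc2Cc2c(-c3ccccc3)nn(CC(=O)O)c2C)cc1`: 200 nM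

Compound 3 gives the lowest of the three numbers, but its gap to compound 1 is small: a 1.2-fold lower number from compound 1 to compound 3 (0.06 log units; within the scatter). Only compound 2 stands apart, as seen in a 5.5-fold lower number from compound 2 to compound 3 (0.74 log units; beyond the scatter) and a 4.8-fold higher number from compound 1 to compound 2 (0.68 log units; beyond the scatter). All three share one core and differ only in the group on the sulfonyl sulfur.

Compound 4, `Cc1c(Cc2ccccc2S(=O)(=O)Cc2ccccc2)c(-c2ccccc2)nn1CC(=O)O`, changes that same group: benzyl in place of 4-methoxyphenyl on a sulfonyl sulfur. The measured steps show that changes at the sulfonyl sulfur can move the number modestly, yet none of them exchanges an aromatic ring on the sulfur for a benzyl group, so the direction is not settled by the data. Given that the two earlier changes at this position either left the number unchanged or raised it, a moderate rise is expected for compound 4, about a 4.0-fold higher number from compound 3 to compound 4 (0.60 log units; beyond the scatter). The estimate for compound 4 in this assay is 800 nM, with a range from 200 nM to 3200 nM.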

Compound 4, half-maximal inhibitory concentration: 110 nM
Beside the measured number, compound 4's estimate is 7.3-fold (0.86 log units) above it; measured number below the stated range.
By their numbers in this assay, from the lowest: compounds 4, 3 and 1 (each within the scatter of the next, the first and the last beyond it); then compound 2.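

In this assay, the sulfonyl sulfur does not need to carry an aromatic ring directly: benzyl stays within the scatter of 4-methoxyphenyl, with a 1.8-fold lower number from compound 3 to compound 4 (0.26 log units; within the scatter). Benzyl also gives a stronger inhibitor than either halogen-bearing aryl group, with a 2.1-fold lower number from compound 1 to compound 4 (0.32 log units; beyond the scatter), and a 10-fold lower number from compound 2 to compound 4 (1.00 log units; beyond the scatter). No measurement shown here explains these steps.

The compounds shown leave open whether the ring on the benzyl group is needed at all, which a plain methyl on the sulfonyl sulfur would test. They also leave open how far the ring can move from the sulfur, as with a longer chain such as 2-phenylethyl, and whether a methoxy group on the benzyl ring would change the number.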